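Phenyl to Benzyl on a Ring Nitrogen: What to Expect

A few compounds are considered here, and "the series" means these few. Any claim that something is new, unique, unknown or untested is made for them only; others in the source may bear on it.

Three compounds sharing the core of compound 1 `Nc1ccccc1NC(=O)c1ccc(CSC(=S)N2CCN(c3ccccc3)CC2)cc1` have been measured in a functional assay on A-375 cells (Homo sapiens) for antiproliferative activity, read by CCK-8 assay, with a stated time of 72 h, tested at 8 uM; on this read-out higher numbers stand for a stronger effect at the one concentration tested and lower numbers for a weaker effect. Compound 1 gives 88.6%, the highest of the three numbers, though the gaps to the other two lie within the scatter. Compound 2 `CN(C(=S)SCc1ccc(C(=O)Nc2ccccc2N)cc1)c1cccnc1` gives 87.7% in this assay, and compound 3 `CN(Cc1cccnc1)C(=S)SCc1ccc(C(=O)Nc2ccccc2N)cc1` gives 83.8% in this assay. Within the data shown here, the single measured step, a number 3.9 percentage points lower from compound 2 to compound 3 (within the scatter), lay within the scatter.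

Compound 4 `Nc1ccccc1NC(=O)c1ccc(CSC(=S)N2CCN(Cc3ccccc3)CC2)cc1` has not yet been measured. It differs from compound 1 by benzyl in place of phenyl on an amine nitrogen in a ring. Among the measured compounds shown here, the one measured step that bears on this change, a number 3.9 percentage points lower from compound 2 to compound 3 (within the scatter), also placed a methylene between an aromatic ring and a nitrogen, and it was small. The account therefore expects no step beyond the scatter in this assay, with at most a slight lowering, a number 2.6 percentage points lower from compound 1 to compound 4 (within the scatter). Compound 4 is estimated to give 86% in this assay, with a range from 74% to 94%.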

Compound 4, a percentage reported as inhibition, at one concentration (the size of the read-out at that concentration, not a potency): 29.3%
Beside the measured number, compound 4's estimate is 56.7 percentage points above it; the whole stated range lies above it.
By their numbers in this assay, from the lowest: compound 4; then compounds 3, 2 and 1 (each within the scatter of the next).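

In this assay, benzyl in place of phenyl on an amine nitrogen in a ring gives a number 59.3 percentage points lower from compound 1 to compound 4 (beyond the scatter) and so shows that this position responds strongly to the change. The earlier step of a number 3.9 percentage points lower from compound 2 to compound 3 (within the scatter) came from (pyridin-3-yl)methyl in place of pyridin-3-yl on an amide-type nitrogen, and its small size does not carry over to the ring nitrogen. Nothing available here gives a measured reason for the size of the new step.

The compounds shown leave open whether the low number belongs to benzyl alone or would also follow from a 2-phenylethyl or methyl group on this nitrogen. Going by these compounds, it also remains open how compound 1 and compound 4 compare in potency, as the read-out reflects a single concentration.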